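The source may report more compounds than this note shows. Statements on the series, on what has been measured and on what is new or still open speak of the compounds shown alone.

Of the compounds shown here, two carrying the same core have been measured in a functional assay on CHO cells for agonist activity at adenosine receptor A1 (Homo sapiens), read by fluorescence and ERK phosphorylation, with stated times of 30 min and 1.5 h, tested at 10 uM; on this read-out lower numbers stand for a weaker effect and higher numbers for a stronger effect at the one concentration tested. Compound 1 `Nc1scc(-c2ccc(F)cc2)c1C(=O)c1ccccc1` gives 60%. Compound 2 `Nc1scc(-c2cccc(Cl)c2)c1C(=O)c1ccccc1` gives 52%, and this number lies within the scatter of compound 1, so the two cannot be told apart. Within the data shown here, the only step seen so far, a number 8 percentage points lower from compound 1 to compound 2 (within the scatter), exchanged one ring for another on the aromatic carbon of the core.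

Compound 3 `Nc1scc(-c2ccc(Cl)cc2)c1C(=O)c1ccccc1` is not yet measured. It differs from compound 2 as follows: 4-chlorophenyl in place of 3-chlorophenyl on an aromatic carbon. Among the measured compounds shown here, no measured step bears directly on moving the chlorine within the ring; the one step, from a fluorinated to a chlorinated ring, stayed within the scatter. A step of similar size is therefore expected, with no direction beyond the scatter.

Compound 3 is estimated at 55%, with a range from 35% to 75%. The expected step is a number 3 percentage points higher from compound 2 to compound 3 (within the scatter).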

Compound 3, a percentage reported as activity, at one concentration (the size of the read-out at that concentration, not a potency): 51%
Compound 3: the middle estimate sits 4 percentage points above what was measured; measured number inside the range.
By their numbers in this assay, from the lowest: compounds 3, 2 and 1 (each within the scatter of the next).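

Moving the chlorine, with 4-chlorophenyl in place of 3-chlorophenyl, gives (a number 1 percentage points lower from compound 2 to compound 3 (within the scatter)) in this assay, so no effect of where the chlorine sits on this ring can be read from these two compounds. Compound 3 also separates the two changes that were mixed in the first step: with the ring position held the same, chloro in place of fluoro gives (a number 9 percentage points lower from compound 1 to compound 3 (within the scatter)), so that exchange cannot be read as a real change either. Nothing available explains these numbers.

From the compounds shown here alone, all three compounds carry a single halogen on the phenyl ring, so it remains open whether a methoxy group, an amine or a carboxylic acid there would move the number beyond the scatter. A single tested concentration also shows only the size of the effect at that concentration and leaves open how the compounds would compare at any other concentration.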